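Sulfamoyl in place of hydrogen on compound 2

This account rests on a few compounds, and the source may have more. Where it says the series, first, only, none or still open, it means among the compounds named here.

Measured compounds:
compound 1 `Fc1ccc(Nc2nccc(-c3ccncc3)n2)cc1`, 1900 nM
compound 2 `c1ccc(Nc2nccc(-c3ccncc3)n2)cc1`, 900 nM
compound 3 `c1ccc(Nc2nccc(-c3cccs3)n2)cc1`, 31700 nM

In a functional assay for inhibition, with Homo sapiens as the target (on this read-out higher numbers stand for weaker inhibition and lower numbers for stronger inhibition), compound 2 gives the lowest of the three numbers; compound 1 is nearest, a 2.1-fold lower number from compound 1 to compound 2 (0.32 log units; beyond the scatter), and compound 3 furthest, a 35-fold higher number from compound 2 to compound 3 (1.55 log units; beyond the scatter). Compound 4 `NS(=O)(=O)c1cccc(Nc2nccc(-c3ccncc3)n2)c1` is not yet measured. It differs from compound 2 by sulfamoyl in place of hydrogen on an aromatic carbon. Within the data shown here, only the step from compound 1 to compound 2 touches the same ring, and it is modest; the step to compound 3 alters a different part and does not bear on this change. Among the measured compounds shown here, no measured step covers a sulfamoyl group. For compound 4 a step of about a 2.3-fold lower number from compound 2 to compound 4 (0.35 log units; beyond the scatter) toward stronger inhibition is expected, with wide uncertainty. Compound 4 is estimated at 400 nM, between 100 nM and 2000 nM.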

Compound 4, half-maximal inhibitory concentration: 500 nM
Compound 4: middle estimate off by 1.3-fold (0.10 log units), on the low side; measured number inside the range.
By their numbers in this assay, from the lowest: compounds 4 and 2 (each within the scatter of the next); then compound 1; then compound 3.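

In this assay the sulfamoyl group, with its 4 heavy atoms, is accommodated on this aromatic carbon, meta to a large group, with a 1.8-fold lower number from compound 2 to compound 4 (0.26 log units; within the scatter). So this position takes a far larger group than hydrogen with no change beyond the scatter, which the fluoro step on this ring could not show. No evidence on the basis of this result is available.

From the compounds shown here alone, whether an amine or a carboxylic acid at this position would also stay within the scatter of compound 2 remains open. So does whether a longer chain carrying the sulfamoyl group would.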